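The source may hold more compounds than are shown below. What is called first, only, known or untested is meant among the compounds shown, and "the series" means these compounds.

Compound 3 `Cn1nccc1-c1cc(C(F)(F)F)ccc1[C@H]1CCOc2cc(S(=O)(=O)Nc3cccnn3)ccc21` gives 915000 nM in a physicochemical assay for solubility (on this read-out lower numbers stand for lower solubility and higher numbers for higher solubility), and so holds the highest number of the three measured compounds. Compound 1 `Cn1nccc1-c1cc(C(F)(F)F)ccc1[C@H]1CCOc2cc(S(=O)(=O)Nc3ncccn3)ccc21` gives 532000 nM, and compound 2 `Cn1nccc1-c1cc(C(F)(F)F)ccc1[C@H]1CCOc2cc(S(=O)(=O)Nc3ccc(F)cn3)ccc21` gives 29000 nM. The step of a 1.7-fold higher number from compound 1 to compound 3 (0.24 log units; within the scatter) lies within the scatter, whereas the steps of an 18-fold lower number from compound 1 to compound 2 (1.26 log units; beyond the scatter) and a 32-fold higher number from compound 2 to compound 3 (1.50 log units; beyond the scatter) are large and beyond it.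

Compound 4 `Cn1nccc1-c1cc(C(F)(F)F)ccc1[C@H]1CCOc2cc(S(=O)(=O)Nc3ccncn3)ccc21` differs from compound 3 in one place: pyrimidin-4-yl in place of pyridazin-3-yl on a sulfonamide nitrogen. Among the measured compounds shown here, no measured step shows this exact exchange. The step that bears most on it is a 1.7-fold higher number from compound 1 to compound 3 (0.24 log units; within the scatter), where one six-membered aromatic ring with 2 hetero atoms replaced another on the sulfonamide nitrogen and this assay moved only within the scatter. The large steps of an 18-fold lower number from compound 1 to compound 2 (1.26 log units; beyond the scatter) and a 32-fold higher number from compound 2 to compound 3 (1.50 log units; beyond the scatter) involve 5-fluoropyridin-2-yl, which plays no part here, so they give no direct guidance. Compound 4 is therefore expected to show a 1.5-fold lower number from compound 3 to compound 4 (0.18 log units; within the scatter), a move within the scatter. The estimate for compound 4 in this assay is 600000 nM, with a range from 180000 nM to 1800000 nM.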

Compound 4, solubility: 1180000 nM
Compound 4: middle estimate off by 2.0-fold (0.29 log units), on the low side, within the range that was stated.
By their numbers in this assay, from the lowest: compound 2; then compounds 1, 3 and 4 (each within the scatter of the next, the first and the last beyond it).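

In this assay, exchanging pyridazin-3-yl for pyrimidin-4-yl on the sulfonamide nitrogen leaves the two compounds indistinguishable (a 1.3-fold higher number from compound 3 to compound 4 (0.11 log units; within the scatter)). Pyrimidin-4-yl and pyrimidin-2-yl, however, do separate, if only modestly (a 2.2-fold higher number from compound 1 to compound 4 (0.35 log units; beyond the scatter)), so this position can register a change between two rings that each count as a six-membered aromatic ring with 2 hetero atoms, which the earlier step between compound 1 and compound 3 did not show. Among the compounds shown here, the gap to the 5-fluoropyridin-2-yl compound is much larger (a 41-fold higher number from compound 2 to compound 4 (1.61 log units; beyond the scatter)) and is the largest step at this position so far.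

No measurement shown accounts for any of these differences. As far as these compounds go, it also remains open whether a methoxy group, a nitrile or an amine on the pyrimidin-4-yl ring would keep the number this high.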